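The source may hold more compounds than are shown below. What is called first, only, known or untested is meant among the compounds shown, and "the series" means these compounds.

Measured so far:
compound 1, `COc1ccccc1N1CCN(CCCCn2cc(-c3ccc(-c4ccccc4)cc3)nn2)CC1`: 425 nM
compound 2, `COc1ccccc1N1CCN(CCCCc2cn(-c3ccc4ccccc4c3)nn2)CC1`: 299 nM
compound 3, `Clc1cccc(N2CCN(CCCCn3cc(-c4ccc(-c5ccccc5)cc4)nn3)CC2)c1Cl`: > 10000 nM

In an assay on HEK293 cells for displacement of a labelled ligand from D(4) dopamine receptor (Homo sapiens), read by scintillation counting, with a stated time of 1 h (on this read-out higher numbers stand for weaker inhibition and lower numbers for stronger inhibition), compound 1 gives 425 nM and compound 2 gives 299 nM; these two values lie within the scatter of each other. Compound 3 reaches only the limit of the assay, > 10000 nM. The change from compound 1 to compound 3 is 2,3-dichlorophenyl in place of 2-methoxyphenyl on an amine nitrogen in a ring, and it produced an at least 23-fold higher number from compound 1 to compound 3 (1.37 log units; beyond the scatter); the step is a bound rather than a number due to the limit of > 10000 nM in this assay, at which 1 of the 3 values shown sits. The cores of compound 1 and compound 2 differ, and that difference is not broken down here.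

Compound 4, `Clc1cccc(N2CCN(CCCCc3cn(-c4ccc5ccccc5c4)nn3)CC2)c1Cl`, is not yet measured in this assay. It stands to compound 2 as compound 3 stands to compound 1: 2,3-dichlorophenyl in place of 2-methoxyphenyl on an amine nitrogen in a ring, the same change at the same place. Given an at least 23-fold higher number from compound 1 to compound 3 (1.37 log units; beyond the scatter), compound 4 is expected to show a step of similar size, a 27-fold higher number from compound 2 to compound 4 (1.43 log units; beyond the scatter). Compound 4 is therefore estimated at 8000 nM, with a range from 3000 nM to 30000 nM, and it may well be reported only as a limit.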

Compound 4, inhibition constant: > 2000 nM
Compound 4 gave a limit, no number; the forecaster's own chance of this, stated with the estimate: 55%; the middle value is on the limit's open side.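

In this assay, 2,3-dichlorophenyl in place of 2-methoxyphenyl on the amine nitrogen weakens inhibition on the core of compound 2 as well, with an at least 6.6-fold higher number from compound 2 to compound 4 (0.82 log units; beyond the scatter), so the direction seen on the core of compound 1 carries over to this second core. The size of the step on the two cores cannot be compared: the same change on two cores in this assay, an at least 23-fold higher number (1.37 log units; beyond the scatter) from compound 1 to compound 3 and an at least 6.6-fold higher number (0.82 log units; beyond the scatter) from compound 2 to compound 4; the limit leaves it open whether they differ. Compound 4 is reported only as a limit, > 2000 nM, and two cores are too few to make this change a rule for the whole series.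

The compounds shown leave open whether an unsubstituted phenyl or a phenyl with a single chlorine on the same amine nitrogen would stay close to the 2-methoxyphenyl compounds or fall away as the 2,3-dichlorophenyl compounds do. They also leave open whether a longer chain on either core would alter the step.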